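Urea series: oxan-4-yl in place of cyclohexyl on the amide

A few compounds are considered here, and "the series" means these few. Any claim that something is new, unique, unknown or untested is made for them only; others in the source may bear on it.

In an in vitro ADME assay on microsomes from liver (Homo sapiens) for metabolic stability, read by LC-MS (a higher number here means that the compound lasts longer, a lower number that the compound disappears faster), compound 1 `Cc1ccc(NC(=O)N2CCCN(C(=O)CCC3CCCC3)CC2)cc1` gives 0.0667 h. Compound 2 `CC(C)(C)c1ccc(NC(=O)N2CCCN(C(=O)C3CCCCC3)CC2)cc1` gives in this assay 0.0667 h, level with compound 1 at the digits shown and within the scatter, so the two values show no difference to speak of. Compound 3 `CC(C)(C)c1ccc(NC(=O)N2CCCN(C(=O)C3CCOCC3)CC2)cc1` is the next member; its change from compound 2 reads (oxan-4-yl in place of cyclohexyl on a carbonyl carbon), or, cut one bond further out, cyclohexylcarbonyl to (oxan-4-yl)carbonyl. Among the measured compounds shown here, no measured pair covers an exchange of this kind, so the size of the step in this assay cannot be read off and is only expected. The expected step is small, if any, towards a longer half-life and probably not beyond the scatter, the expected change from compound 2 to compound 3 being a 1.3-fold higher number from compound 2 to compound 3 (0.13 log units; within the scatter). For compound 3 the estimate in this assay is 0.09 h, with a range from 0.05 h to 0.25 h.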

Compound 3, half-life: 0.183 h
Compound 3: the middle estimate sits 2.0-fold (0.31 log units) below what was measured; the range from low to high includes it.
By their numbers in this assay, from the lowest: compounds 1 and 2 (each within the scatter of the next); then compound 3.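

Among the compounds shown here, this is the first reading at this position, since compounds 1 and 2 differ in more than one place and gave no step for a single exchange. On a carbonyl carbon, oxan-4-yl in place of cyclohexyl gives in this assay a 2.7-fold higher number from compound 2 to compound 3 (0.44 log units; beyond the scatter), so this one exchange moves the half-life clear of the scatter, with both groups holding 6 heavy atoms and oxan-4-yl adding the ring oxygen as 1 hydrogen-bond acceptor. No measurement at hand bears on what lies behind the step.

On these data alone, the step rests on a single pair, so whether it carries over to other amide groups remains open. Also open, as far as these compounds go, is how a ring holding an amine, such as piperidin-4-yl, or a cyclohexyl bearing a carboxylic acid would read at the same place.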